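The source may hold more compounds than are shown below. What is called first, only, known or untested is meant among the compounds shown, and "the series" means these compounds.

Working notes on the series. Compound 1 `Cc1cccc(Cl)c1NC(=O)CN1CCN(c2nnc(Cc3ccncc3)c3ccccc23)CC1` is the reference point. In a functional assay on MDA-MB-231 cells (Homo sapiens) for cytotoxicity, read by MTT assay, with a stated time of 72 h (on this read-out higher numbers stand for weaker inhibition and lower numbers for stronger inhibition), compound 1 gives 2670 nM, the lowest of the three numbers in hand. Compound 2 `Cc1ccc(F)cc1NC(=O)CN1CCN(c2nnc(Cc3ccccc3)c3ccccc23)CC1` gives 19200 nM and compound 3 `O=C(CN1CCN(c2nnc(Cc3ccccc3)c3ccccc23)CC1)Nc1ccc(Br)cc1` gives 12400 nM; both stand beyond the scatter above compound 1, compound 3 the nearer of the two and compound 2 the furthest. Among the measured compounds shown here, the one single-point step measured so far, a 1.5-fold lower number from compound 2 to compound 3 (0.19 log units; within the scatter), exchanges one aryl group on the amide-type nitrogen for another and stays within the scatter. Compounds 2 and 3 also differ from compound 1 elsewhere in the structure, so that step bears on the present question only loosely.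

Compound 4 `Cc1ccccc1NC(=O)CN1CCN(c2nnc(Cc3ccncc3)c3ccccc23)CC1` differs from compound 1 by hydrogen in place of chloro on an aromatic carbon, the 2-chloro-6-methylphenyl becoming 2-methylphenyl. For the measured compounds named here, no measured step removes a chloro from the aryl on the amide-type nitrogen with all else held constant; the step from compound 2 to compound 3 is the only guide and indicates that changes on this aryl can be small. Compound 4 is therefore expected to drift somewhat weaker, the estimated step being a 1.7-fold higher number from compound 1 to compound 4 (0.23 log units; within the scatter). The estimated value for compound 4 in this assay is 4500 nM, with a range from 2000 nM to 10000 nM.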

Compound 4, half-maximal inhibitory concentration: 200 nM
Estimate against measurement, compound 4: 23-fold (1.35 log units) above, outside the stated range (below it).
By their numbers in this assay, from the lowest: compound 4; then compound 1; then compounds 3 and 2 (each within the scatter of the next).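

In this assay, the step of a 13-fold lower number from compound 1 to compound 4 (1.13 log units; beyond the scatter) shows that the aryl on the amide-type nitrogen is not a place where changes are always small, which is all that a 1.5-fold lower number from compound 2 to compound 3 (0.19 log units; within the scatter) had suggested. With the rest of the structure held constant, the loss of a single chloro, one heavy atom with no hydrogen-bond donor or acceptor counted, ortho to a large group and meta to the methyl group, is enough to carry a step well beyond the scatter, so the 2-methylphenyl is a clear advance on the 2-chloro-6-methylphenyl in this assay. No measurement in hand bears on why removing this chloro has so large an effect.

The compounds shown leave open whether the lower number depends on the methyl group that remains, a question that the unsubstituted phenyl would address, and whether hydrogen is the best group on this aromatic carbon or a methoxy or an amine would do as well. They also leave open whether the same exchange carries the same size of step on the core of compound 2, where a different group stands on the far side of the molecule.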